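From a dimethylamino chain to a hydroxyethyl carbamoyl

The source may hold more compounds than are shown below. What is called first, only, known or untested is meant among the compounds shown, and "the series" means these compounds.

In a functional assay on HCT-116 cells (Homo sapiens) for antiproliferative activity, read by sulforhodamine B assay, with a stated time of 72 h (a lower number here means a stronger inhibitor, a higher number a weaker inhibitor), two compounds sharing one core have been measured. Compound 1 `CNC(=O)C[C@@H]1C[C@@H](c2ccc(Cl)c(Cl)c2)[C@H](NC(=O)c2cc(-c3c(Cl)cnn3C)c(Cl)o2)CN1` gives 450 nM, and compound 2 `CN(C)CC[C@@H]1C[C@@H](c2ccc(Cl)c(Cl)c2)[C@H](NC(=O)c2cc(-c3c(Cl)cnn3C)c(Cl)o2)CN1` gives 1710 nM, the higher of the two numbers and so the weaker result. Compound 3 `Cn1ncc(Cl)c1-c1cc(C(=O)N[C@@H]2CN[C@H](CC(=O)NCCO)C[C@H]2c2ccc(Cl)c(Cl)c2)oc1Cl` has (2-hydroxyethyl)carbamoyl in place of (dimethylamino)methyl on a saturated chain carbon bound to a saturated ring carbon. Going by the values given here, one measured step bears on this change. Putting (dimethylamino)methyl in place of methylcarbamoyl at that same place gives a 3.8-fold higher number from compound 1 to compound 2 (0.58 log units; beyond the scatter). Compound 3 holds a carbamoyl group there, as does compound 1 at 450 nM, so a number nearer to that value is expected. Among the compounds with values here, still, no measured compound carries the hydroxyethyl end, and a single step is thin support. In this assay a modest fall is therefore expected, estimated as a 2.6-fold lower number from compound 2 to compound 3 (0.42 log units; beyond the scatter). For compound 3 the estimated value is 650 nM, with an expected range from 250 nM to 1700 nM.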

Compound 3, half-maximal inhibitory concentration: 670 nM
Estimate against measurement, compound 3: 1.0-fold (0.01 log units) below; the measured number falls inside the stated range.
By their numbers in this assay, from the lowest: compounds 1 and 3 (each within the scatter of the next); then compound 2.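

In this assay, the change from the (dimethylamino)methyl group to the (2-hydroxyethyl)carbamoyl group gives a 2.6-fold lower number from compound 2 to compound 3 (0.41 log units; beyond the scatter). Going by these compounds alone, compound 2 now stands apart from two carbamoyl compounds rather than one, so the earlier gap no longer rests on the single methylcarbamoyl group of compound 1. The end of the amide also proves tolerant in this small set: adding hydroxymethyl on the saturated chain carbon bound to the amide-type nitrogen gives a 1.5-fold higher number from compound 1 to compound 3 (0.17 log units; within the scatter), so the two carbamoyl compounds cannot be told apart in this assay, and the added hydroxyl group brings no measurable gain or loss.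

Still open, on these data alone, is how far this tolerance extends, for example to an unsubstituted carboxamide, a carboxylic acid in place of the amide, or a longer chain such as a 3-hydroxypropyl group on the amide nitrogen. Nothing measured here explains why both carbamoyl compounds give lower numbers than compound 2.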